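The compounds below may be only part of what the source reports. "The series", "measured", "known", "first", "only" and "open" are said of these compounds alone.

Measured in a physicochemical assay for solubility, with a stated time of 4 h, at pH 7.4; on this read-out lower numbers stand for lower solubility and higher numbers for higher solubility:
- Compound 1 `CNC(=O)c1cc(N)c(Nc2ccc(C#N)cc2)cc1Oc1c(C)cc(CCC#N)cc1C`: 8.28 ug/mL
- Compound 2 `Cc1cc(CCC#N)cc(C)c1Oc1cc(Nc2ccc(C#N)cc2)c(N)cc1C(F)(F)F`: 0.24 ug/mL

Compound 2 has the lower of these two numbers. Compound 3 `COC(=O)c1cc(N)c(Nc2ccc(C#N)cc2)cc1Oc1c(C)cc(CCC#N)cc1C` has yet to be measured, and it carries methoxycarbonyl in place of trifluoromethyl on an aromatic carbon. Among the compounds with values here, the one measured step that bears on this change, a 35-fold lower number from compound 1 to compound 2 (1.54 log units; beyond the scatter), is large and came with trifluoromethyl in place of methylcarbamoyl. Within the data shown here, no measured compound carries methoxycarbonyl, so only part of that gap is expected to return in this assay. The expected change is a 7.5-fold higher number from compound 2 to compound 3 (0.88 log units; beyond the scatter), upward and beyond the scatter. For compound 3 the estimate is 1.8 ug/mL, with an expected range of 0.5 ug/mL to 6.5 ug/mL.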

Compound 3, solubility: 1.21 ug/mL
The estimate for compound 3 lay 1.5-fold (0.17 log units) above the measured number; measured number inside the range.
By their numbers in this assay, from the lowest: compound 2; then compound 3; then compound 1.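

At this aromatic carbon in this assay, methoxycarbonyl in place of trifluoromethyl gives a 5.0-fold higher number from compound 2 to compound 3 (0.70 log units; beyond the scatter), so a carbonyl-bearing group here recovers part of the gap between compound 2 and compound 1. Methoxy in place of methylamino on the carbonyl carbon gives a 6.8-fold lower number from compound 1 to compound 3 (0.84 log units; beyond the scatter), so the two carbonyl-bearing groups are not interchangeable at this position. Nothing available explains either step. On these data alone, whether a carboxylic acid or a primary amide here would fall outside the range spanned by compound 2 and compound 1 remains open. So does whether ethoxycarbonyl would stay close to compound 3.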